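The compounds below may be only part of what the source reports. "The series", "measured", "known", "first", "only" and "open" are said of these compounds alone.

Measured in a physicochemical assay for solubility, at pH 6.8; on this read-out higher numbers stand for higher solubility and lower numbers for lower solubility:

- compound 1 `CN1CCc2nc(C(=O)NC3CNCCC3NC(=O)c3cc4cc(Cl)ccc4[nH]3)sc2C1` gives 996 ug/mL
- compound 2 `COC(=O)CN1CC[C@H](NC(=O)c2cc3cc(Cl)ccc3[nH]2)[C@H](NC(=O)c2nc3c(s2)CN(C)CC3)C1` gives 28 ug/mL
- compound 3 `CN1CCc2nc(C(=O)NC3CCN(C(=O)OC(C)(C)C)CC3NC(=O)c3cc4cc(Cl)ccc4[nH]3)sc2C1` gives < 1 ug/mL, a limit and not a number

Compound 3 therefore has no exact position on this read-out. Among the compounds with values here, it is the only compound of the three at the limit: the limit of < 1 ug/mL in this assay, at which 1 of the 3 values shown sits.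

The next compound is compound 4 `CN1CCc2nc(C(=O)NC3CCNCC3NC(=O)c3cc4cc(Cl)ccc4[nH]3)sc2C1`, which has hydrogen in place of tert-butoxycarbonyl on an amine nitrogen in a ring. Within the data shown here, no step between measured compounds is available as a direct guide, so the expectation rests on what the three values show.

Compound 1 also carries hydrogen on an amine nitrogen in a ring and gives 996 ug/mL, which makes it the closest reference for compound 4. Compound 2 has a substituted ring nitrogen and gives 28 ug/mL. Among the measured compounds shown here, with only three compounds, this is a tentative comparison and not an established pattern.

A rise in this assay well beyond the usual scatter is expected, with the estimated change being an at least 700-fold higher number from compound 3 to compound 4 (2.84 log units; beyond the scatter). The value expected for compound 4 is 700 ug/mL, with an estimated range from 150 ug/mL to 2000 ug/mL.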

Compound 4, solubility: 830 ug/mL
The estimate for compound 4 lay 1.2-fold (0.07 log units) below the measured number; low and high end bracket the measured number.
By their numbers in this assay, from the lowest: compound 2; then compounds 4 and 1 (each within the scatter of the next). At a limit, below all of these: compound 3.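

In this assay, hydrogen in place of tert-butoxycarbonyl on the amine nitrogen in the six-membered non-aromatic ring gives an at least 830-fold higher number from compound 3 to compound 4 (2.91 log units; beyond the scatter), the only direct step at this position among the compounds shown. Compound 1 gives 996 ug/mL and compound 4 gives 830 ug/mL, two values within the scatter of each other, and both compounds carry hydrogen on an amine nitrogen in a ring. Compound 3 stands at a limit and not at a number, so this step sets a minimum size and not an exact one: the limit of < 1 ug/mL in this assay, at which 1 of the 4 values shown sits.

Within the data shown here, the single step compares hydrogen with tert-butoxycarbonyl only, so it remains open whether a methyl, an acetyl or a short chain ending in a carboxylic acid on the same nitrogen would give values close to that of compound 4 or close to the limit of compound 3. Going by these compounds, the true size of the step also remains open, and compound 2 cannot settle either question, as it differs from compound 4 in more than one place.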